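Trifluoromethyl for fluoro on the sulfonyl phenyl

The source may report more compounds than this note shows. Statements on the series, on what has been measured and on what is new or still open speak of the compounds shown alone.

Compound 2 `O=S(=O)(NCCNc1nccc(-c2c(-c3cccc(F)c3)nc3sccn23)n1)c1ccc(F)cc1` gives 9450 nM in a functional assay on A-375 cells (Homo sapiens) for cytotoxicity, read by MTT assay; a higher number here means a weaker inhibitor, a lower number a stronger inhibitor. Of the three measured compounds, it lies within the scatter of both others: compound 1 `O=S(=O)(NCCCNc1nccc(-c2c(-c3cccc(F)c3)nc3sccn23)n1)c1ccc(F)cc1` gives 14500 nM, and compound 3 `O=S(=O)(NCCCNc1nccc(-c2c(-c3cccc(F)c3)nc3sccn23)n1)c1ccc(Cl)cc1` gives 5900 nM. The step of a 1.5-fold lower number from compound 1 to compound 2 (0.19 log units; within the scatter) and the step of a 1.6-fold lower number from compound 2 to compound 3 (0.20 log units; within the scatter) both stay within the scatter; only a 2.5-fold lower number from compound 1 to compound 3 (0.39 log units; beyond the scatter) goes beyond it, and that step is modest.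

Compound 4 `O=S(=O)(NCCNc1nccc(-c2c(-c3cccc(F)c3)nc3sccn23)n1)c1ccc(C(F)(F)F)cc1` differs from compound 2 by trifluoromethyl in place of fluoro on an aromatic carbon. Among the measured compounds shown here, the one measured step that bears on this change is a 2.5-fold lower number from compound 1 to compound 3 (0.39 log units; beyond the scatter), which exchanges the same fluoro for chloro on the same aromatic carbon. For the measured compounds named here, no measured step exchanges fluoro for trifluoromethyl, so the size for this group is not known from the series and the range must stay wide. The expectation is a step in the same direction and of about the same size as the fluoro-to-chloro step, namely a 2.1-fold lower number from compound 2 to compound 4 (0.32 log units; beyond the scatter) in this assay. Compound 4 is therefore estimated at 4500 nM, with a range from 1500 nM to 14000 nM.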

Compound 4, half-maximal inhibitory concentration: 7440 nM
Compound 4: middle estimate off by 1.7-fold (0.22 log units), on the low side, within the range that was stated.
By their numbers in this assay, from the lowest: compounds 3, 4, 2 and 1 (each within the scatter of the next, the first and the last beyond it).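

Trifluoromethyl in place of fluoro, para to a large group, gives in this assay a 1.3-fold lower number from compound 2 to compound 4 (0.10 log units; within the scatter), so the change from 1 heavy atom to 4 at this aromatic carbon produces no readable shift. Among the compounds shown here, until now the only exchange at this carbon was fluoro to chloro, a 2.5-fold lower number from compound 1 to compound 3 (0.39 log units; beyond the scatter), which was read on the other chain; the second substituent tried here does not repeat a step beyond the scatter. Nothing available explains this result.

Open, as far as these compounds go, is whether chloro and trifluoromethyl would read differently on one and the same chain, since compound 3 and compound 4 differ in two places. Also open, from the compounds shown here alone, is how an amine, a carboxylic acid or a methoxy group on this aromatic carbon would read in this assay.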